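The source may report more compounds than this note shows. Statements on the series, on what has been measured and on what is new or still open speak of the compounds shown alone.

Measured compounds in a functional assay on NCI-H226 cells (Homo sapiens) for inhibition, read by sulforhodamine B assay, with a stated time of 48 h; a higher number here means a weaker inhibitor of growth, a lower number a stronger inhibitor of growth:
Compound 1 `O=C(Nc1cccc(-n2cc(-c3ccncc3)c(-c3ccc(Cl)c(O)c3)n2)c1)Nc1cccc(C(F)(F)F)c1` gives > 32500 nM, which is a limit of the assay and not a number.
Compound 2 `COc1cc(-c2nn(-c3cccc(NC(=O)Nc4cc(C(F)(F)F)cc(C(F)(F)F)c4)c3)cc2-c2ccncc2)ccc1Cl` gives 21800 nM.
Compound 3 `COc1cc(-c2nn(-c3cccc(NC(=O)c4cccc(C(F)(F)F)c4)c3)cc2-c2ccncc2)ccc1Cl` gives 27000 nM.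

Compound 3 holds the higher of the two numbers in this assay, but its gap to compound 2 sits within the scatter, so no order between the two is claimed. The value of compound 1 is a limit and is not compared. Compound 4 `COc1cc(-c2nn(-c3cccc(NC(=O)Nc4ccc(Cl)c(Cl)c4)c3)cc2-c2ccncc2)ccc1Cl` carries (3,4-dichlorophenyl)amino in place of 3-(trifluoromethyl)phenyl on a carbonyl carbon, so that the carbonyl of compound 3 becomes, as in compound 2, part of a carbamoyl. Compound 2 is the only other carbamoyl with a number in this assay, and its value lies close to that of compound 3. Among the measured compounds shown here, no measured pair isolates this change, so the step is expected to stay within the scatter, with no direction preferred: a 1.3-fold lower number from compound 3 to compound 4 (0.11 log units; within the scatter) is the expected step. Compound 4 is therefore estimated at 21000 nM, within 8000 nM to 45000 nM.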

Compound 4, concentration for total growth inhibition: > 50000 nM
Compound 4 ended at the assay's limit; the forecaster's own chance of this, stated with the estimate: 30%; middle value at least 2.3-fold (0.37 log units) away from the limit.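

In this assay, from the compounds shown here alone, (3,4-dichlorophenyl)amino in place of 3-(trifluoromethyl)phenyl on a carbonyl carbon gives an at least 1.8-fold higher number from compound 3 to compound 4 (0.26 log units; that floor lies within the scatter), so this change yields no stronger inhibitor of growth, while the size of any loss stays unknown. The result for compound 4 is a limit of the assay and not a number: the limit of > 50000 nM in this assay, at which 1 of the 4 values shown sits.

The change swaps the amino link and the ring substituents together, and the compounds shown do not separate the two. Also open, going by these compounds, is how a morpholine or a carboxylic acid would read at this place.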